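A few compounds are considered here, and "the series" means these few. Any claim that something is new, unique, unknown or untested is made for them only; others in the source may bear on it.

Working notes on the series. In an assay for inhibition of Indoleamine 2,3-dioxygenase 1 (Homo sapiens), read by fluorescence, with a stated time of 1 h (a higher number here means a weaker inhibitor, a lower number a stronger inhibitor), compound 1 `CS(=O)(=O)NCCSc1nonc1/C(=N/O)Nc1ccc(F)c(Br)c1` gives 270 nM, while compound 2 `NS(=O)(=O)NCCOc1nonc1/C(=N/O)Nc1ccc(F)c(Br)c1` gives 150 nM. On these two numbers compound 1 stands highest, its nearest neighbour being compound 2 at a 1.8-fold lower number from compound 1 to compound 2 (0.26 log units; within the scatter), a gap within the scatter. The new entry, compound 3 `CS(=N)(=O)CC(=O)NCCSc1nonc1/C(=N/O)Nc1ccc(F)c(Br)c1`, differs from compound 1 by a group of 7 heavy atoms (3 carbon, 1 nitrogen, 2 oxygen, 1 sulfur; no ring) in place of a group of 4 heavy atoms (1 carbon, 2 oxygen, 1 sulfur; no ring), on an amine nitrogen. Among the measured compounds shown here, the only measured step, a 1.8-fold lower number from compound 1 to compound 2 (0.26 log units; within the scatter), alters the chain on the aromatic carbon of the shared core together with its terminal sulfur group rather than the substituent on the amine nitrogen alone, so it bears only loosely on this change, and it was itself within the scatter. For the measured compounds named here, no measured step therefore gives grounds to expect a shift beyond the scatter in this assay in either direction. Compound 3 is expected to give 270 nM, with a range from 110 nM to 700 nM. For compound 3 the step so estimated is no change at the digits printed from compound 1 to compound 3 (within the scatter).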

Compound 3, half-maximal inhibitory concentration: 61 nM
For compound 3 the middle estimate is 4.4-fold (0.65 log units) above the measured one; the measured number lies below the stated range.
By their numbers in this assay, from the lowest: compound 3; then compounds 2 and 1 (each within the scatter of the next).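

Working notes, continued. On the amine nitrogen whose other neighbour is a saturated chain carbon, putting the 7-heavy-atom group in place of methylsulfonyl gives a 4.4-fold lower number from compound 1 to compound 3 (0.65 log units; beyond the scatter) in this assay. Among the compounds shown here, this is the first step beyond the scatter and the first to change the substituent on that nitrogen alone, so this position can move the number, and a larger group is accepted there without loss. No measurement in hand accounts for the lower number.

As far as these compounds go, it remains open which part of the entering group carries the step, and a plain acetyl group on the same nitrogen would help separate the carbonyl and added chain from the sulfur-bearing end. Also open, from the compounds shown here alone, is whether the same group would give a comparable step on the chain of compound 2.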